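Compound 3: One Group Changed, One Number Awaited

The source may hold more compounds than are shown below. What is called first, only, known or untested is meant among the compounds shown, and "the series" means these compounds.

In a physicochemical assay for lipophilicity, read by LC-MS, in phosphate buffer, measured as octanol-water partition, with a stated time of 30 min, at pH 7.4, tested at 200 mM (on this read-out lower numbers stand for lower lipophilicity and higher numbers for higher lipophilicity), compound 2 `Cc1cccnc1Oc1ccc2nc(COc3cccc(C(=O)O)c3)n(C)c2c1` gives 0.9, within the scatter of compound 1 `Cn1c(COc2cccc(C(=O)O)c2)nc2ccc(Oc3cccc(Cl)n3)cc21` at 1.2. Compound 3 `Cn1c(COc2cccc(C(=O)O)c2)nc2ccc(Oc3ncc(Cl)cc3F)cc21` differs from compound 2 by 5-chloro-3-fluoropyridin-2-yl in place of 3-methylpyridin-2-yl on an oxygen on an aromatic ring. Going by the values given here, the one measured step that bears on this is a number 0.30 log units lower from compound 1 to compound 2 (within the scatter), which put 3-methylpyridin-2-yl in place of 6-chloropyridin-2-yl and stayed within the scatter. The expected step is therefore small and upward, a number 0.30 log units higher from compound 2 to compound 3 (within the scatter), no larger than the scatter. The estimated value for compound 3 is 1.2, with an expected range of 0.8 to 1.6.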

Compound 3, distribution coefficient: 1.3
The estimate for compound 3 lay 0.10 log units below the measured number; the measured number falls inside the stated range.
By their numbers in this assay, from the lowest: compounds 2, 1 and 3 (each within the scatter of the next, the first and the last beyond it).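

In this assay, going by these compounds alone, a change of the group on this oxygen can move the number beyond the scatter: 5-chloro-3-fluoropyridin-2-yl in place of 3-methylpyridin-2-yl gives a number 0.40 log units higher from compound 2 to compound 3 (beyond the scatter) and is the first such step here. In place of 6-chloropyridin-2-yl, the same group gives a number 0.10 log units higher from compound 1 to compound 3 (within the scatter) and so stays within the scatter. No measurement offered here accounts for either step. Going by these compounds, it remains open what 5-chloropyridin-2-yl or 3-fluoropyridin-2-yl would give on this oxygen, each carrying only one of the two halogens. On these data alone, an aminopyridine in this place is equally open.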